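A few compounds are considered here, and "the series" means these few. Any claim that something is new, unique, unknown or untested is made for them only; others in the source may bear on it.

Measured so far in a functional assay, tested at 100 ug/mL; a higher number here means a stronger effect of the compound at the concentration tested, a lower number a weaker effect:

- compound 1, `O=S(=O)(CC1=NCCO1)c1c(-c2ccccc2)nn(-c2ccccc2)c1-c1ccccc1`: 59.1%
- compound 2, `COc1ccc(C2=NOC(c3ccc(C)cc3)C2S(=O)(=O)CC2=NCCO2)cc1`: 70.9%
- compound 3, `COc1ccc(C2=NOC(c3ccc(C)cc3)C2S(=O)(=O)CC2=NCCS2)cc1`: 52.6%

Compound 2 gives the highest of the three numbers in this assay. Compound 1 and compound 3 lie within the scatter of each other, so no order between them is claimed; compound 1 stands beyond the scatter only against compound 2.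

Compound 2 and compound 3 share a core and differ in one place: a group of 5 heavy atoms (3 carbon, 1 nitrogen, 1 sulfur; one five-membered non-aromatic ring with 2 hetero atoms) in place of a group of 5 heavy atoms (3 carbon, 1 nitrogen, 1 oxygen; one five-membered non-aromatic ring with 2 hetero atoms), on a saturated chain carbon bound to a sulfonyl sulfur. This change made the step of a number 18.3 percentage points lower from compound 2 to compound 3 (beyond the scatter), a modest loss that lies beyond the scatter.

Compound 1 rests on a different core; the difference between the two cores is not broken down here.

Compound 4, `O=S(=O)(CC1=NCCS1)c1c(-c2ccccc2)nn(-c2ccccc2)c1-c1ccccc1`, is not yet measured. It arises from compound 1 by a group of 5 heavy atoms (3 carbon, 1 nitrogen, 1 sulfur; one five-membered non-aromatic ring with 2 hetero atoms) in place of a group of 5 heavy atoms (3 carbon, 1 nitrogen, 1 oxygen; one five-membered non-aromatic ring with 2 hetero atoms), on a saturated chain carbon bound to a sulfonyl sulfur. The place is the same as in the pair above, so this is the same change, seen here for the second time. Among the measured compounds shown here, only the one measured instance of it is available, and it sits on a different core, so its transfer to compound 1 is uncertain.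

For compound 4 the expected step in this assay is a number 16.1 percentage points lower from compound 1 to compound 4 (beyond the scatter), resting on the earlier step of a number 18.3 percentage points lower from compound 2 to compound 3 (beyond the scatter) and on the value of compound 1, 59.1%. The estimated value for compound 4 is 43%, with a range expected from 27% to 59%.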

Compound 4, a percentage reported as activity, at one concentration (the size of the read-out at that concentration, not a potency): "not active" (no number reported)
For compound 4 the study gives words and no number; the estimate stays without a comparison.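

In this assay, among the compounds shown here, compound 4 is reported only in words, as not active, so no step from compound 1 to compound 4 can be read. The compounds shown leave open whether the same group change on the core of compound 1 compares in size with a number 18.3 percentage points lower from compound 2 to compound 3 (beyond the scatter). Nothing shown bears on the reason for this result.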